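A few compounds are considered here, and "the series" means these few. Any claim that something is new, unique, unknown or untested is made for them only; others in the source may bear on it.

Two compounds share a core built around a sugar-bearing ring and a methyl ester, and both were tested in a functional assay on SK-BR-3 cells (Homo sapiens) for antiproliferative activity, read by MTT assay, with a stated time of 72 h; on this read-out lower numbers stand for stronger inhibition and higher numbers for weaker inhibition. Compound 1 `C/C=C1/[C@H](O[C@@H]2O[C@H](CO)[C@@H](O)[C@H](O)[C@H]2O)OC=C(C(=O)OC)[C@H]1CC(=O)OCCc1ccc(O)c(O)c1` carries a free sugar and a catechol-bearing ethyl ester; in this assay compound 1 gives 160000 nM, a weak result. Compound 2 `C/C=C1/[C@H](O[C@@H]2O[C@H](COC(C)=O)[C@@H](OC(C)=O)[C@H](OC(C)=O)[C@H]2OC(C)=O)OC=C(C(=O)OC)[C@H]1CC(=O)OCC` carries an acetylated sugar and a plain ethyl ester. In this assay compound 2 gives only a limit of the assay, > 15000 nM, so its true value is not known; compound 2 sits at the limit of > 15000 nM in this assay, at which 1 of the 2 values shown sits, and no numerical comparison to compound 1 can be drawn from it.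

Compound 3 `C/C=C1/[C@H](O[C@@H]2O[C@H](COC(C)=O)[C@@H](OC(C)=O)[C@H](OC(C)=O)[C@H]2OC(C)=O)OC=C(C(=O)OC)[C@H]1CC(=O)SCCc1ccccc1` has not yet been measured. It differs from compound 2 at the ester: phenethylsulfanyl in place of ethoxy on a carbonyl carbon. For the measured compounds named here, since compound 2 stands only at a limit, no measured step is available to guide the size of the change; the move to compound 3 is expected to bring a modest gain, a step that the limit leaves unreadable from compound 2 to compound 3, though a result still at a limit remains a real possibility. Compound 3 is expected to give about 30000 nM, within a range from 8000 nM to 150000 nM.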

Compound 3, half-maximal inhibitory concentration: > 15000 nM
Compound 3: only a limit was reported; the forecaster's own chance of this, stated with the estimate: 50%; the middle value does not contradict the limit.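

Compound 2 and compound 3 both give only a limit and not a number, so no step between them can be read: the limit of > 15000 nM in this assay, at which 2 of the 3 values shown sit.

The compounds shown leave open what the true values of compound 2 and compound 3 are, and whether phenethylsulfanyl in place of ethoxy on a carbonyl carbon changes the result in this assay at all.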